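The compounds below may be only part of what the source reports. "The series", "measured", "known", "first", "only" and "open" are said of these compounds alone.

Measured compounds:
- compound 1, `Cc1oc(-c2ccccc2Cl)nc1CN1CCC(C(=O)NCCCN2C[C@H](C)C[C@H](C)C2)CC1`: > 72 ug/mL
- compound 2, `Cc1ccccc1-c1nc(CN2CCC(C(=O)N3CCN(C4CCN(C)CC4)CC3)CC2)c(C)o1`: > 71 ug/mL

Both values come from a physicochemical assay for solubility, in phosphate buffer, measured as kinetic solubility, at pH 7.4; on this read-out higher numbers stand for higher solubility and lower numbers for lower solubility. For compound 1 the reading of > 72 ug/mL is a limit of this assay, not a number. For compound 2 the reading of > 71 ug/mL is likewise a limit. So compound 1 stands at the ceiling of what this assay reports, and the only other compound shown sits at a ceiling as well the limit of > 71 ug/mL in this assay, at which 1 of the 2 values shown sits (the limit of > 72 ug/mL in this assay, at which 1 of the 2 values shown sits); no measured step between two compounds exists here, and no value that the assay actually resolved.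

Compound 3, `COc1cccc(Cl)c1-c1nc(CN2CCC(C(=O)NCCCN3C[C@H](C)C[C@H](C)C3)CC2)c(C)o1`, has not yet been measured in this assay. It differs from compound 1 in one place: methoxy in place of hydrogen on an aromatic carbon. The group enters on an aromatic carbon of a six-membered aromatic ring of carbon only, ortho to a large group and meta to a chloro group, so the 2-chlorophenyl of compound 1 becomes a 2-chloro-6-methoxyphenyl.

Among the measured compounds shown here, with no resolved number for compound 1 and no measured step to lean on, the step expected for compound 3 in this assay is an at least 1.0-fold lower number from compound 1 to compound 3 (0.01 log units; that floor lies within the scatter), a change not clearly beyond the scatter in either direction. Compound 3 is therefore estimated at 70 ug/mL, within a range of 30 ug/mL to 150 ug/mL.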

Compound 3, solubility: > 76 ug/mL
Compound 3: only a limit was reported; the forecaster's own chance of this, stated with the estimate: 55%; at least 1.0-fold (0.03 log units) between middle value and limit.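

In this assay compound 3 gives > 76 ug/mL, which is a limit of the assay and not a number. Compound 1 gives > 72 ug/mL, also a limit, so no step can be read between compound 1 and compound 3. The compounds shown leave open where the true values lie and whether methoxy in place of hydrogen changes the read-out at all.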